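Phenyl for 1-methylethenyl on an acyl urea: expected cytotoxicity

A few compounds are considered here, and "the series" means these few. Any claim that something is new, unique, unknown or untested is made for them only; others in the source may bear on it.

Measured compounds:
compound 1, `CCNC(=O)NC1=CS(=O)(=O)O[C@@]12[C@@H](CO[Si](C)(C)C(C)(C)C)O[C@@H](n1cc(C)c(=O)n(C)c1=O)[C@@H]2O[Si](C)(C)C(C)(C)C`: 10000 nM
compound 2, `COC(=O)CNC1=CS(=O)(=O)O[C@@]12[C@@H](CO[Si](C)(C)C(C)(C)C)O[C@@H](n1cc(C)c(=O)n(C)c1=O)[C@@H]2O[Si](C)(C)C(C)(C)C`: 160000 nM
compound 3, `C=C(C)C(=O)NC(=O)NC1=CS(=O)(=O)O[C@@]12[C@@H](CO[Si](C)(C)C(C)(C)C)O[C@@H](n1cc(C)c(=O)n(C)c1=O)[C@@H]2O[Si](C)(C)C(C)(C)C`: 1200 nM

All three share one core and differ only in the group on the ring nitrogen. In a functional assay on HEL cells (Homo sapiens) (on this read-out lower numbers stand for higher toxicity in this test and higher numbers for lower toxicity in this test), compound 3 gives the lowest number of the three, so it is the most toxic here: its nearest neighbour is compound 1, with an 8.3-fold lower number from compound 1 to compound 3 (0.92 log units; beyond the scatter) separating them, and its furthest is compound 2, with a 130-fold lower number from compound 2 to compound 3 (2.12 log units; beyond the scatter).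

Compound 4, `Cc1cn([C@@H]2O[C@H](CO[Si](C)(C)C(C)(C)C)[C@@]3(OS(=O)(=O)C=C3NC(=O)NC(=O)c3ccccc3)[C@H]2O[Si](C)(C)C(C)(C)C)c(=O)n(C)c1=O`, has not yet been measured. It differs from compound 3 in one place:
phenyl in place of 1-methylethenyl on a carbonyl carbon
The acyl urea motif itself is kept; only the group on its outer carbonyl carbon changes.

The step that bears most on this is an 8.3-fold lower number from compound 1 to compound 3 (0.92 log units; beyond the scatter), which shows that adding a carbonyl-bearing group to the urea nitrogen of compound 1 gave a modest move to a lower number. Within the data shown here, no measured pair shows what swapping one such carbonyl substituent for another does. Since compound 4 keeps the acyl urea of compound 3, the expected step in this assay is none beyond the scatter, in either direction: a 1.3-fold higher number from compound 3 to compound 4 (0.10 log units; within the scatter). The estimate for compound 4 in this assay is therefore 1500 nM, within a range from 400 nM to 6000 nM.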

Compound 4, half-maximal cytotoxic concentration: >= 200000 nM
Compound 4 gave a limit, no number; the forecaster's own chance of this, stated with the estimate: 5%; middle value at least 130-fold (2.12 log units) from the limit.
By their numbers in this assay, from the lowest: compound 3; then compound 1; then compound 2. At a limit, above all of these: compound 4.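

In this assay compound 4 gives a limit and not a number: the limit of >= 200000 nM in this assay, at which 1 of the 4 values shown sits. Keeping the acyl urea is therefore not enough to keep the low number of compound 3, as phenyl in place of 1-methylethenyl on the carbonyl carbon gives an at least 160-fold higher number from compound 3 to compound 4 (2.22 log units; beyond the scatter), so the group on this carbon matters a great deal in this test. The same compound also lands well clear of the simple urea, with an at least 20-fold higher number from compound 1 to compound 4 (1.30 log units; beyond the scatter), while an at least 1.2-fold higher number from compound 2 to compound 4 (0.09 log units; that floor lies within the scatter) has a floor within the scatter, so those last two compounds cannot be put in order.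

The compounds shown leave open whether this large step belongs to the aromatic ring of phenyl or to the loss of the double bond of 1-methylethenyl, a question that an isopropyl or a cyclohexyl group on the same carbonyl carbon would help to settle. Also open, from the compounds shown here alone, is how a pyridyl ring or a phenyl carrying a methoxy group would behave at this position, and what the actual number for compound 4 is.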